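Compound 4: carboxymethyl in place of isopropyl

The compounds below may be only part of what the source reports. "The series", "measured", "known", "first", "only" and "open" are said of these compounds alone.

Measured in a functional assay on the whole organism (Tail, strain ICR) with Mus musculus as the target, in the tail flick test, with a stated time of 120 min, at a dose of 25 umol/kg by the oral route; on this read-out higher numbers stand for a stronger effect at the one dose given and lower numbers for a weaker effect:
compound 1, `O=C(CN(c1nc(Cl)nc2[nH]cnc12)C1CC1)N[C@@H](CO)C(=O)O`, gives 39%
compound 2, `O=C(O)CNC(=O)CN(c1nc(Cl)nc2[nH]cnc12)C1CC1`, gives 19.8%
compound 3, `CC(C)[C@H](NC(=O)CN(c1nc(Cl)nc2[nH]cnc12)C1CC1)C(=O)O`, gives 17.1%

Compound 3 has the lowest of the three numbers; its gap to compound 2 is within the scatter, so the two cannot be ordered, while compound 1 stands clearly higher, shown by a number 21.9 percentage points lower from compound 1 to compound 3 (beyond the scatter).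

Compound 4, `O=C(O)C[C@H](NC(=O)CN(c1nc(Cl)nc2[nH]cnc12)C1CC1)C(=O)O`, is not yet measured. It differs from compound 3 thus: carboxymethyl in place of isopropyl on a saturated chain carbon bound to an amide-type nitrogen and a carbonyl carbon. Among the measured compounds shown here, the steps that bear on this change are a number 2.7 percentage points lower from compound 2 to compound 3 (within the scatter), which is within the scatter, and a number 21.9 percentage points lower from compound 1 to compound 3 (beyond the scatter), which is not. For the measured compounds named here, both steps end at the isopropyl group of compound 3; no measured step involves a carboxymethyl group, so the size of the coming step is uncertain. The one substituent bearing a hydrogen-bond donor and acceptor, the hydroxymethyl of compound 1, gave the highest number.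

Compound 4 is therefore expected to return toward that level, with an estimated step of a number 10.9 percentage points higher from compound 3 to compound 4 (beyond the scatter). Compound 4 is estimated at 28%, in the range 12% to 45%.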

Compound 4, a percentage reported as activity, at one dose (the size of the read-out at that dose, not a potency): 22%
For compound 4 the middle estimate is 6 percentage points above the measured one; low and high end bracket the measured number.
By their numbers in this assay, from the lowest: compounds 3, 2 and 4 (each within the scatter of the next); then compound 1.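

In this assay carboxymethyl at this saturated chain carbon does not stand apart from isopropyl or hydrogen, with a number 4.9 percentage points higher from compound 3 to compound 4 (within the scatter) and a number 2.2 percentage points higher from compound 2 to compound 4 (within the scatter) as the two steps. Carboxy in place of hydroxy gives a clearer result, with a number 17 percentage points lower from compound 1 to compound 4 (beyond the scatter) on the same read-out, so the hydrogen-bond donor and acceptor of carboxymethyl are not enough on their own to reach the level of compound 1. No measurement at hand accounts for the gap between hydroxymethyl and carboxymethyl.

On these data alone, whether the higher number of compound 1 depends on the hydroxy group itself stays open; a 2-hydroxyethyl chain, a methoxymethyl group or an aminomethyl group at this carbon would test that. As far as these compounds go, with one dose and one time point for each compound, how the effect of the series changes with dose and over time also remains open.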